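Truncating the Aryl Ether in a Triazole Sulfonamide Series

The source may report more compounds than this note shows. Statements on the series, on what has been measured and on what is new or still open speak of the compounds shown alone.

Measured compounds:
Compound 1 `COc1cc2c(cc1OC)CN(S(=O)(=O)c1ccc(-n3cc(COc4ccccc4C)nn3)cc1)CC2`: 39700 nM
Compound 2 `COc1cc2c(cc1OC)CN(S(=O)(=O)c1ccc(-n3cc(COc4cc(C=O)ccc4OC)nn3)cc1)CC2`: 76200 nM

In a functional assay on HuCC-A1 cells (Homo sapiens) for cytotoxicity, read by MTT assay, with a stated time of 48 h (on this read-out higher numbers stand for weaker inhibition and lower numbers for stronger inhibition), compound 1 gives 39700 nM and compound 2 gives 76200 nM. Compound 2 has the higher of the two numbers, but the step of a 1.9-fold higher number from compound 1 to compound 2 (0.28 log units; within the scatter) lies within the scatter, so the two cannot be told apart on this read-out. Compound 3 `COc1cc2c(cc1OC)CN(S(=O)(=O)c1ccc(-n3cc(CO)nn3)cc1)CC2` has not yet been measured. Its change from compound 2 is hydrogen in place of 5-formyl-2-methoxyphenyl on an oxygen on a saturated carbon; cut one bond further out, the difference reads 5-formyl-2-methoxyphenoxy to hydroxy. Going by the values given here, the only measured step swaps one aryl group for another and keeps the ether, so no measured step bears directly on removing the aryl group entirely. Both measured compounds sit in a narrow weak band and nothing in the data points to a large shift. Compound 3 is therefore expected at 90000 nM with a range of 30000 nM to 270000 nM, an expected step of a 1.2-fold higher number from compound 2 to compound 3 (0.07 log units; within the scatter).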

Compound 3, half-maximal inhibitory concentration: 72000 nM
Estimate against measurement, compound 3: 1.3-fold (0.10 log units) above; the range from low to high includes it.
By their numbers in this assay, from the lowest: compounds 1, 3 and 2 (each within the scatter of the next).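

In this assay, taking the aryl group off the oxygen altogether gives a 1.1-fold lower number from compound 2 to compound 3 (0.02 log units; within the scatter) and does not separate the pair, and the same removal from the other aryl ether gives a 1.8-fold higher number from compound 1 to compound 3 (0.26 log units; within the scatter) with the same outcome. The earlier pair had only exchanged one aryl group for another, whereas these steps show that on this read-out a plain hydroxymethyl cannot be told apart from either aryl ether, so the aryl group as a whole makes no readable difference at this place. No outside measurement bears on this result.

The three compounds leave open whether any other group here, such as an amine, a carboxylic acid or a longer chain in place of the hydroxy, would give a step beyond the scatter. They also leave open how changes to the shared core would read.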